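Extending the carbamate ester of compound 3 toward a carbonyloxy chain

The source may report more compounds than this note shows. Statements on the series, on what has been measured and on what is new or still open speak of the compounds shown alone.

Of the compounds shown here, three sharing one core have been measured in an assay for inhibition of serine/threonine-protein kinase PAK 4 (Homo sapiens), read by FRET and Z'-LYTE, with a stated time of 60 min, tested at 5 uM, in the presence of a further agent that is not named here; on this read-out lower numbers stand for a weaker effect and higher numbers for a stronger effect at the one concentration tested. Compound 1 `CC(C)COC(=O)N1CCN(C(=O)c2nc(Nc3cc(C4CC4)[nH]n3)c3cc(Cl)ccc3n2)C[C@H]1C` gives 30.7%. Compound 2 `CC(C)C(=O)OCOC(=O)N1CCN(C(=O)c2nc(Nc3cc(C4CC4)[nH]n3)c3cc(Cl)ccc3n2)C[C@H]1C` gives 51.6%. Compound 3 `C[C@@H]1CN(C(=O)c2nc(Nc3cc(C4CC4)[nH]n3)c3cc(Cl)ccc3n2)CCN1C(=O)OC(C)(C)C` gives 22.7%, the lowest of the three numbers; its gap to compound 1 is within the scatter, while its gap to compound 2 is beyond it.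

Compound 4 `CC(OC(=O)N1CCN(C(=O)c2nc(Nc3cc(C4CC4)[nH]n3)c3cc(Cl)ccc3n2)C[C@H]1C)OC(=O)C(C)(C)C` differs from compound 3 in one place: 1-(((tert-butyl)carbonyl)oxy)ethyl in place of tert-butyl on an oxygen next to a carbonyl group. The new group sits on an oxygen next to a carbonyl group.

Going by the values given here, two measured steps bear on this change. Adding a carbonyloxy unit to the ester chain gave a number 20.9 percentage points higher from compound 1 to compound 2 (beyond the scatter). Going the other way, from that carbonyloxy-bearing chain to a plain tert-butyl gave a number 28.9 percentage points lower from compound 2 to compound 3 (beyond the scatter). Both point the same way: a carbonyloxy unit in the ester chain was paired with a higher number. The change to compound 4 brings in a carbonyloxy unit of this kind, so a modest rise beyond the scatter is expected, roughly back toward the value of compound 2.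

Compound 4 is therefore expected to give about 45%, with a likely range from 25% to 65%. That estimate amounts to an expected step of a number 22.3 percentage points higher from compound 3 to compound 4 (beyond the scatter).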

Compound 4, a percentage reported as inhibition, at one concentration (the size of the read-out at that concentration, not a potency): 23.6%
Beside the measured number, compound 4's estimate is 21.4 percentage points above it; the measured number lies below the stated range.
By their numbers in this assay, from the lowest: compounds 3, 4 and 1 (each within the scatter of the next); then compound 2.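

In this assay, the step of a number 0.9 percentage points higher from compound 3 to compound 4 (within the scatter) shows that swapping tert-butyl for 1-(((tert-butyl)carbonyl)oxy)ethyl on this oxygen does not separate the two compounds, and the step of a number 7.1 percentage points lower from compound 1 to compound 4 (within the scatter) shows the same against isobutyl. A carbonyloxy unit in the ester chain is therefore not enough by itself to go with a higher number: compound 2 carries one and stands apart, whereas compound 4 carries one and does not, as the step of a number 28 percentage points lower from compound 2 to compound 4 (beyond the scatter) makes plain. What matters at this position is thus the particular chain, not merely the presence of that unit, and nothing available explains the difference between these two chains.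

Compound 2 and compound 4 differ in two features at once, a methyl against an ethyl linking unit and an isopropyl against a tert-butyl end, so the compounds shown cannot say which of the two accounts for the gap. It also remains open how a chain ending in a carboxylic acid or an amine would behave on this oxygen, and how any of these compounds would rank across a range of concentrations.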